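A few compounds are considered here, and "the series" means these few. Any claim that something is new, unique, unknown or untested is made for them only; others in the source may bear on it.

- compound 1 `O=C(CCc1cccc2c1B(O)OC2)Nc1cccc(-c2ccccc2)c1` in an ADME assay on WI-38 cells (Homo sapiens) for cytotoxicity, read by MTT assay, with a stated time of 72 h (a higher number here means a weaker inhibitor, a lower number a stronger inhibitor), gives 12000 nM
- compound 2 `O=C(CCc1cccc2c1B(O)OC2)Nc1cccc(-c2cccc(F)c2)c1` in this assay gives 37000 nM
- compound 3 `O=C(CCc1cccc2c1B(O)OC2)Nc1cccc(-c2cccc(Cl)c2)c1` in this assay gives 58000 nM

Compound 3 stands level with compound 2 within the scatter, and both carry higher numbers than compound 1. The next compound to be measured is compound 4 `CSc1cccc(-c2cccc(NC(=O)CCc3cccc4c3B(O)OC4)c2)c1` and it differs from compound 3 by methylsulfanyl in place of chloro on an aromatic carbon with methylsulfanyl in place of chloro on an aromatic carbon, meta to a large group.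

Among the compounds with values here, three measured steps bear on this change. Adding a substituent to compound 1 gave modest steps, a 3.1-fold higher number from compound 1 to compound 2 (0.49 log units; beyond the scatter) for fluoro and a 4.8-fold higher number from compound 1 to compound 3 (0.68 log units; beyond the scatter) for chloro. The exchange closest to the one at hand, chloro in place of fluoro, gave a 1.6-fold higher number from compound 2 to compound 3 (0.20 log units; within the scatter) and so did not separate the two compounds. Within the data shown here, no measured compound carries methylsulfanyl, so the data give no direct reading for this group and no direction for the step. A substituent exchange is therefore expected to stay within the scatter, with a wide margin for the untested group. The estimated step is a 1.3-fold lower number from compound 3 to compound 4 (0.11 log units; within the scatter) in this assay and no shift beyond the scatter is expected. For compound 4 the expected value is 45000 nM with an estimated range from 18000 nM to 110000 nM in this assay as the working figure.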

Compound 4, half-maximal inhibitory concentration: 2000 nM
Estimate against measurement, compound 4: 23-fold (1.35 log units) above; measured number below the stated range.
By their numbers in this assay, from the lowest: compound 4; then compound 1; then compounds 2 and 3 (each within the scatter of the next).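

In this assay, this place on the aromatic ring, meta to a large group, proves far more sensitive to the substituent than fluoro and chloro suggested: a 29-fold lower number from compound 3 to compound 4 (1.46 log units; beyond the scatter) and a 19-fold lower number from compound 2 to compound 4 (1.27 log units; beyond the scatter) set methylsulfanyl well apart from the two halogens, which stayed within the scatter of each other. The direction of the change also differs, since a 3.1-fold higher number from compound 1 to compound 2 (0.49 log units; beyond the scatter) and a 4.8-fold higher number from compound 1 to compound 3 (0.68 log units; beyond the scatter) both point upward from the unsubstituted compound, whereas a 6.0-fold lower number from compound 1 to compound 4 (0.78 log units; beyond the scatter) points the other way, so adding a group here does not raise the number in every case. The material at hand gives no measured basis for explaining this reversal.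

The compounds shown leave open whether the lower number follows the sulfur atom itself or the methylsulfanyl group as a whole, a question on which a methoxy group or an ethylsulfanyl group in the same place would bear. On these data alone, it also remains open whether methylsulfanyl has a similar effect at other places on this aromatic ring.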